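Replacing an Aromatic Ring with a Non-Aromatic One

A few compounds are considered here, and "the series" means these few. Any claim that something is new, unique, unknown or untested is made for them only; others in the source may bear on it.

Within the data shown here, in a functional assay on MCF-10A cells (Homo sapiens) for antiproliferative activity, with a stated time of 48 h (a higher number here means that more compound is needed for the effect, a lower number that less compound is needed), compound 2 `COc1ccc2nc(C)cc(NCc3cccnc3)c2c1` gives 49300 nM and stands level with compound 1 `COc1ccc2nc(C)cc(NCc3ccncc3)c2c1` which gives 41600 nM at the high end of the three numbers so far. Compound 3 `COc1ccc2nc(C)cc(NCc3ccc(C(C)(C)C)cc3)c2c1` gives 7000 nM and so needs clearly less compound than either of them.

Compound 4 `COc1ccc2nc(C)cc(NCC3CCCN(C)C3)c2c1` keeps the shared core but carries 1-methylpiperidin-3-yl in place of pyridin-3-yl on a saturated chain carbon bound to a nitrogen on an aromatic ring. Among the measured compounds shown here, the one measured step that bears on this change is a 1.2-fold higher number from compound 1 to compound 2 (0.07 log units; within the scatter) where pyridin-3-yl took the place of pyridin-4-yl. That step stayed within the scatter, but it only compares two aromatic rings. For the measured compounds named here, no measured compound has a non-aromatic ring at this place, so the guidance is indirect. The distance to compound 3 at 7000 nM shows that the group here can matter, which widens the range.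

No shift beyond the scatter is expected in this assay and the estimated change is a 1.4-fold lower number from compound 2 to compound 4 (0.15 log units; within the scatter) in this reading. For compound 4 the estimated value is 35000 nM with expected bounds of 12000 nM and 90000 nM around it.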

Compound 4, half-maximal effective concentration: 5800 nM
For compound 4 the middle estimate is 6.0-fold (0.78 log units) above the measured one, and the stated range ends above it.
By their numbers in this assay, from the lowest: compounds 4 and 3 (each within the scatter of the next); then compounds 1 and 2 (each within the scatter of the next).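

In this assay, among these compounds, 1-methylpiperidin-3-yl on the saturated chain carbon is the first non-aromatic ring at this place, and it moves the result well beyond the scatter (an 8.5-fold lower number from compound 2 to compound 4 (0.93 log units; beyond the scatter)), with much the same picture against the other pyridine compound (a 7.2-fold lower number from compound 1 to compound 4 (0.86 log units; beyond the scatter)). Exchanging one pyridine ring for the other had left the number within the scatter, so this position responds to replacing the aromatic ring itself far more than to shifting the ring nitrogen, and less compound is needed for the effect with the non-aromatic ring. Compound 4 also stands level with compound 3, so two quite different groups at this place, one of them non-aromatic and one aromatic, reach the same range, although no measurement here explains why the change has this effect.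

From the compounds shown here alone, the change swaps the ring type and adds a methyl group in a single step, so the contribution of each stays open. Plain piperidin-3-yl, cyclohexyl or 1-methylpiperidin-4-yl at this place would help to separate these contributions and show how much the ring nitrogen and its point of attachment matter.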